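The source may hold more compounds than are shown below. What is called first, only, known or untested is meant among the compounds shown, and "the series" means these compounds.

Of the compounds shown here, three have been tested in a functional assay on SW-620 cells (Homo sapiens) for antiproliferative activity, read by MTT assay, with a stated time of 72 h (a lower number here means a stronger inhibitor, a higher number a weaker inhibitor), so far. Compound 1 `O=C1O/C(=C\Cn2cc(-c3ccc(Br)cc3)nn2)C(OCc2ccccc2)=C1OCc1ccccc1` reaches only the limit of the assay, giving > 100000 nM. Compound 3 `CC(C)(C)OC(=O)N1CCN(C(=S)SCc2cn(C[C@H](O)[C@H]3OC(=O)C(OCc4ccccc4)=C3OCc3ccccc3)nn2)CC1` likewise stops at a limit, with > 100000 nM. Only compound 2 `CCCCc1cn(C[C@H](O)[C@H]2OC(=O)C(OCc3ccccc3)=C2OCc2ccccc2)nn1` returns an actual number: in this assay compound 2 gives 47500 nM. Compound 2 therefore stands alone among the numbers shown; the other two values are limits, and the limit of > 100000 nM in this assay, at which 2 of the 3 values shown sit, describes where both of them sit. Going by the values given here, no pair of measured compounds differs in just one place, so no measured step can be read from these three.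

Compound 4 `O=C1O[C@H]([C@@H](O)Cn2cc(-c3cc(F)cc(F)c3)nn2)C(OCc2ccccc2)=C1OCc1ccccc1` has not yet been measured. It differs from compound 2 as follows: 3,5-difluorophenyl in place of butyl on an aromatic carbon. Among the compounds with values here, with no measured step of this kind to lean on, the expectation for compound 4 in this assay can rest only on the single number of compound 2 and on the fact that the other two compounds sit at a limit. The step from compound 2 to compound 4 is expected to be small, a 1.3-fold higher number from compound 2 to compound 4 (0.10 log units; within the scatter), not clearly beyond the usual scatter in either direction. For compound 4 the estimate in this assay is 60000 nM, with a range from 15000 nM to 250000 nM.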

Compound 4, half-maximal inhibitory concentration: > 100000 nM
Compound 4 was reported as a limit; the forecaster's own chance of this, stated with the estimate: 35%; at least 1.6-fold (0.22 log units) between middle value and limit.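

Going by these compounds alone, with 3,5-difluorophenyl in place of butyl on an aromatic carbon of the five-membered aromatic ring with 3 nitrogen, this assay gives the first readable step: an at least 2.1-fold higher number from compound 2 to compound 4 (0.32 log units; beyond the scatter). The step shows that this position is not indifferent to what it carries, since exchanging the open chain for a fluorinated aromatic ring does not preserve the measurable activity of compound 2, which gives 47500 nM. Compound 4 ends at a limit rather than at a number, so the true size of the loss stays unknown, and the compound joins most of the others shown: the limit of > 100000 nM in this assay, at which 3 of the 4 values shown sit.

Butyl remains the only group here with a measured number, but a single pair cannot show whether the chain itself matters or whether this one aromatic ring is simply a poor replacement. A longer chain such as octyl, a shorter one such as ethyl, an unsubstituted phenyl or a chain ending in an amine at this position would help separate these two readings.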